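Cytotoxicity of a fused aminonitrile series against Ehrlich cells

This account rests on a few compounds, and the source may have more. Where it says the series, first, only, none or still open, it means among the compounds named here.

Measured compounds:
- compound 1, `N#CC1=C(N)N(c2ccc(S(N)(=O)=O)cc2)C2=C(CCCC2)C1c1ccccc1`: 30%
- compound 2, `COc1ccccc1C1C(C#N)=C(N)N(c2ccc(S(N)(=O)=O)cc2)C2=C1CCCC2`: 100%
- compound 3, `COc1ccc(C2C(C#N)=C(N)N(c3ccc(S(N)(=O)=O)cc3)C3=C2CCCC3)cc1`: 100%

In a functional assay on Ehrlich cells (Mus musculus) for cytotoxicity, read by trypan blue exclusion, with a stated time of 2 h, tested at 100 ug/mL (a higher number here means a stronger effect of the compound at the concentration tested, a lower number a weaker effect), compound 1 gives 30%, the lowest of the three numbers shown. Compound 2 lies a number 70 percentage points higher from compound 1 to compound 2 (beyond the scatter) and compound 3 lies a number 70 percentage points higher from compound 1 to compound 3 (beyond the scatter); both steps are large and beyond the scatter, and both consist of a methoxy group in place of hydrogen on an aromatic carbon of the phenyl that sits on the saturated ring carbon of the shared core. Between compound 2 and compound 3 there is no change at the digits printed from compound 2 to compound 3 (within the scatter), so moving the methoxy group from one aromatic carbon to another did not matter at the digits printed.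

Compound 4, `N#CC1=C(N)N(c2ccc(S(N)(=O)=O)cc2)C2=C(CCCC2)C1c1ccc(Cl)c(Cl)c1`, has not yet been measured. It differs from compound 1 as follows: 3,4-dichlorophenyl in place of phenyl on a saturated ring carbon. For the measured compounds named here, the steps that bear on this change are the two from compound 1, since both also alter the substitution of that phenyl, and both rose sharply. Going by the values given here, no measured step introduces chlorine, so the size of the effect of the 3,4-dichlorophenyl is not known from the data. An upward step is nevertheless expected, and compound 4 is estimated at 75%, between 35% and 100%, meaning an expected step of a number 45 percentage points higher from compound 1 to compound 4 (beyond the scatter).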

Compound 4, a percentage reported as activity, at one concentration (the size of the read-out at that concentration, not a potency): 50%
For compound 4 the middle estimate is 25 percentage points above the measured one, and the stated range covers the measured number.
By their numbers in this assay, from the lowest: compound 1; then compound 4; then compounds 2 and 3 (each within the scatter of the next).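

In this assay, 3,4-dichlorophenyl in place of phenyl on the saturated ring carbon also raises the number (a number 20 percentage points higher from compound 1 to compound 4 (beyond the scatter)), so at this position a rise is not tied to methoxy and now appears with chlorine on the phenyl as well. The substituent's identity matters here and not merely the presence of one, since the 3,4-dichlorophenyl falls well short of the 4-methoxyphenyl (a number 50 percentage points lower from compound 3 to compound 4 (beyond the scatter)) and of the 2-methoxyphenyl (a number 50 percentage points lower from compound 2 to compound 4 (beyond the scatter)). Nothing available accounts for this gap between the chlorine-bearing and methoxy-bearing phenyls.

The compounds shown leave open whether a single chlorine on the phenyl behaves like the pair, and whether a hydroxyl, an amine or a carboxylic acid on that ring would sit nearer the methoxy compounds or nearer compound 4. Also open, as far as these compounds go, is how compound 2, compound 3 and compound 4 would separate at lower concentrations, as a read-out at one concentration gives no potency.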